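A Hydroxy in Place of the Methoxy on Compound 1

The source may hold more compounds than are shown below. What is called first, only, known or untested is meant among the compounds shown, and "the series" means these compounds.

Measured so far:
compound 1 `CCCCOc1ccc(C(=O)n2c(C)c(CC(=O)O)c3cc(OC)ccc32)cc1` — 4700 nM
compound 2 `CCCCOc1ccc(C(=O)n2c(C)c(CCCCC(=O)O)c3cc(OC)ccc32)cc1` — 5200 nM

In an assay on isolated protein for binding affinity to prostaglandin E2 receptor EP2 subtype (Mus musculus) (on this read-out higher numbers stand for weaker inhibition and lower numbers for stronger inhibition), compound 1 gives 4700 nM and compound 2 gives 5200 nM; the step of a 1.1-fold higher number from compound 1 to compound 2 (0.04 log units; within the scatter) lies within the scatter, so the two stand together. Compound 3 `CCCCOc1ccc(C(=O)n2c(C)c(CC(=O)O)c3cc(O)ccc32)cc1` differs from compound 1 by hydrogen in place of methyl on an oxygen on an aromatic ring. No measured step touches this oxygen; the one step shown concerns the chain, and it gives no guide to the change. With nothing to point either way, compound 3 is expected to give about 5000 nM, between 1500 nM and 16000 nM. The expected step of a 1.1-fold higher number from compound 1 to compound 3 (0.03 log units; within the scatter) would stay within the scatter.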

Compound 3, inhibition constant: 3300 nM
For compound 3 the middle estimate is 1.5-fold (0.18 log units) above the measured one, and the stated range covers the measured number.
By their numbers in this assay, from the lowest: compounds 3, 1 and 2 (each within the scatter of the next).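

The step from methoxy to hydroxy gives a 1.4-fold lower number from compound 1 to compound 3 (0.15 log units; within the scatter) in this assay, so the two compounds stand together. This is the first sign that this oxygen on an aromatic ring can carry either methyl or hydrogen without a step beyond the scatter, as the chain step had shown for the 3-carboxypropyl change. Nothing measured here explains this result.

On these data alone, whether an amine, a fluorine or a longer alkoxy chain in place of the hydroxy would stand with these compounds remains open. So does the reading of hydroxy alongside the 3-carboxypropyl change of compound 2.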